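A few compounds are considered here, and "the series" means these few. Any claim that something is new, unique, unknown or untested is made for them only; others in the source may bear on it.

Measured so far:
compound 1 `Clc1ccc(-c2cc(-c3cccnc3)nc(-c3cccs3)c2)o1` — 14600 nM
compound 2 `Cc1ccccc1-c1cc(-c2ccc(Cl)o2)cc(-c2ccsc2)n1` — 9770 nM

Both numbers come from a functional assay on HeLa cells (Homo sapiens) for cytotoxicity, in the presence of a further agent that is not named here; on this read-out higher numbers stand for weaker inhibition and lower numbers for stronger inhibition. Compound 1 carries the higher of the two numbers, but compound 2 lies within the scatter of it, so the two cannot be put in order; both sit at weak inhibition on this read-out. For the measured compounds named here, the two differ in more than one place, so no single step can be drawn between them, and the series so far gives no step of any kind to lean on.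

Compound 3 `Clc1ccc(-c2cc(-c3cccs3)nc(-c3ccccc3Cl)c2)o1` is not yet measured in this assay. Against compound 1 its difference is 2-chlorophenyl in place of pyridin-3-yl on an aromatic carbon. Neither measured compound carries this exchange, so the measured numbers say nothing about its size or direction. With compound 1 at 14600 nM as the only starting point, the step is expected to be none beyond the scatter: a 1.2-fold lower number from compound 1 to compound 3 (0.09 log units; within the scatter). Compound 3 is accordingly estimated at 12000 nM, with a range from 4000 nM to 40000 nM.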

Compound 3, half-maximal inhibitory concentration: 18500 nM
For compound 3 the middle estimate is 1.5-fold (0.19 log units) below the measured one; the range from low to high includes it.
By their numbers in this assay, from the lowest: compounds 2, 1 and 3 (each within the scatter of the next).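

Notes on the position next to the ring nitrogen: in this assay, 2-chlorophenyl in place of pyridin-3-yl gives a 1.3-fold higher number from compound 1 to compound 3 (0.10 log units; within the scatter), the first step in the series that can be read at a single place. At this position, a carbon-only aromatic ring with 0 hydrogen-bond acceptors can therefore stand in for a ring with 1 hydrogen-bond acceptor without the number leaving the scatter, and the ring nitrogen of pyridin-3-yl is not shown to matter for this read-out within the pair of compound 1 and compound 3. No measurement at hand on either group bears on this result.

For the compounds shown here, still open is whether a group of a different kind at this position, such as an amine, a carboxylic acid or a longer alkyl chain, would give a step beyond the scatter, since the only exchange seen here is between two six-membered aromatic rings and all the numbers remain at weak inhibition. Going by these compounds alone, the contributions of the 5-chlorofuran-2-yl and thiophen-2-yl groups are also open, as no step at either place is available.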